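Solubility notes: from compound 3 to compound 4

The source may report more compounds than this note shows. Statements on the series, on what has been measured and on what is new or still open speak of the compounds shown alone.

Measured so far:
- compound 1, `CNC(=O)c1cc(C(=O)NC2CC2)cn(Cc2cccc3cn[nH]c23)c1=O`: in a physicochemical assay for solubility (a higher number here means a more soluble compound, a lower number a less soluble compound), compound 1 is reported only as a limit, >= 181 ug/mL.
- compound 2, `CNC(=O)c1cc(C(=O)NC2CC2)cn(Cc2cccc(F)c2)c1=O`: in this assay compound 2 is likewise reported only as a limit, >= 133 ug/mL.
- compound 3, `CNC(=O)c1cc(C(=O)NC2CC2)cn(Cc2ccc(C)cc2)c1=O`: in this assay compound 3 gives 24 ug/mL.

Among the measured compounds shown here, compound 3 thus carries the only actual number in the set; the other two values are limits. Two readable steps both end at the 4-methylphenyl compound: an at least 7.5-fold lower number from compound 1 to compound 3 (0.87 log units; beyond the scatter) and an at least 5.5-fold lower number from compound 2 to compound 3 (0.74 log units; beyond the scatter). The remaining pair cannot be sized, a step that the two limits leave unreadable from compound 1 to compound 2, since one end sits at the limit of >= 133 ug/mL in this assay, at which 1 of the 3 values shown sits, and the other at the limit of >= 181 ug/mL in this assay, at which 1 of the 3 values shown sits.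

The next compound is compound 4, `CNC(=O)c1cc(C(=O)NC2CC2)cn(Cc2cccc(C)c2)c1=O`. The change is 3-methylphenyl in place of 4-methylphenyl on a saturated chain carbon bound to an aromatic nitrogen. For the measured compounds named here, none of the measured steps exchanges one methylphenyl for another; each replaces the 4-methylphenyl group with a different ring entirely, so no measured step bears directly on this change. With the same atoms joined differently, the expected step is a 1.5-fold higher number from compound 3 to compound 4 (0.16 log units; within the scatter), none beyond the scatter. Compound 4 is therefore estimated at 35 ug/mL, with a range from 14 ug/mL to 90 ug/mL.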

Compound 4, solubility: >= 205 ug/mL
Compound 4: only a limit was reported (the forecaster's own chance of this, stated with the estimate: 5%); at least 5.8-fold (0.76 log units) between middle value and limit.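

With the same atoms joined differently, 3-methylphenyl in place of 4-methylphenyl on a saturated chain carbon bound to an aromatic nitrogen gives an at least 8.5-fold higher number from compound 3 to compound 4 (0.93 log units; beyond the scatter) in this assay, so the reading at this position depends on how the methyl is placed and not only on which ring is present. Compound 4 is reported only as a limit, >= 205 ug/mL. Compound 3 is now the only one of the four with an actual number, which ties its low reading to the 4-methylphenyl group and not to a methyl as such.

What an aminomethyl group or a carboxylic acid in place of the methyl would give in this assay remains open, as does any reason for the difference between the two methylphenyl groups. The steps from compound 1 and from compound 2 to compound 4 cannot be read, since both ends of each are limits: the limit of >= 205 ug/mL in this assay, at which 1 of the 4 values shown sits.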